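The source may report more compounds than this note shows. Statements on the series, on what has been measured and on what is new or still open speak of the compounds shown alone.

In a functional assay on B16-F10 cells (Mus musculus) for antiproliferative activity, read by MTT assay, with a stated time of 48 h (a higher number here means a weaker inhibitor, a lower number a stronger inhibitor), compound 1 `COc1ccc(/C=C/c2cc(OC)cc(OC)c2/C=C/C(=O)c2cccc(OC)c2)cc1` gives 4.3 ug/mL, compound 2 `CCCCOc1ccc(C(=O)/C=C/c2c(/C=C/c3ccc(OC)cc3)cc(OC)cc2OC)cc1` gives 5.3 ug/mL and compound 3 `COc1ccc(/C=C/c2cc(OC)cc(OC)c2/C=C/C(=O)c2ccc(Cl)cc2)cc1` gives 4.9 ug/mL. Compound 3 therefore stands within the scatter of both other compounds. Compound 4 `COc1ccc(/C=C/c2cc(OC)cc(OC)c2/C=C/C(=O)c2ccc(-c3ccccc3)cc2)cc1` has phenyl in place of chloro on an aromatic carbon, a change of 4-chlorophenyl to 4-phenylphenyl: phenyl in place of chloro on an aromatic carbon.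

Within the data shown here, three measured steps bear on this change. Changing the aryl group on the carbonyl carbon gave a 1.2-fold higher number from compound 1 to compound 2 (0.09 log units; within the scatter) and also a 1.1-fold higher number from compound 1 to compound 3 (0.06 log units; within the scatter). Among the measured compounds shown here, the closest precedent, chloro in place of butoxy on an aromatic carbon, gave a 1.1-fold lower number from compound 2 to compound 3 (0.03 log units; within the scatter). For the measured compounds named here, no measured compound carries phenyl at this place, so the expectation rests on these small steps alone and its range is kept wide. Judging from the step of a 1.1-fold lower number from compound 2 to compound 3 (0.03 log units; within the scatter), no change beyond the scatter is expected in this assay. The estimated step is a 1.0-fold higher number from compound 3 to compound 4 (0.01 log units; within the scatter). Compound 4 is expected to give 5 ug/mL, with an estimated range from 2.8 ug/mL to 9 ug/mL.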

Compound 4, half-maximal inhibitory concentration: 10.6 ug/mL
The estimate for compound 4 lay 2.1-fold (0.33 log units) below the measured number, outside the stated range (above it).
By their numbers in this assay, from the lowest: compounds 1, 3, 2 and 4 (each within the scatter of the next, the first and the last beyond it).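

In this assay the earlier swaps of the aryl group on the carbonyl carbon all stayed within the scatter, but putting phenyl where chloro stood, on an aromatic carbon para to a large group, gives a 2.2-fold higher number from compound 3 to compound 4 (0.34 log units; beyond the scatter) and so moves beyond it. The step to 4-phenylphenyl from 3-methoxyphenyl, a 2.5-fold higher number from compound 1 to compound 4 (0.39 log units; beyond the scatter), is also modest but beyond the scatter, while compound 2 goes against the pattern, since phenyl in place of butoxy gives a 2.0-fold higher number from compound 2 to compound 4 (0.30 log units; within the scatter) and stays within it. No measurement shown here accounts for these steps.

Going by these compounds, whether an amine, a carboxylic acid or an alkoxy chain longer than butoxy at this place would stay close to compound 3 remains open. So does whether a second ring of another kind, such as pyridine, would behave as phenyl does.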